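One Benzyl Group for Another in a Cytotoxicity Series

A few compounds are considered here, and "the series" means these few. Any claim that something is new, unique, unknown or untested is made for them only; others in the source may bear on it.

Of the compounds shown here, three have so far been measured in a functional assay on A549 cells (Homo sapiens) for cytotoxicity, read by MTT assay, with a stated time of 72 h; a higher number here means a weaker inhibitor, a lower number a stronger inhibitor. Compound 1 `O=Cc1cn(Cc2ccc(Cl)cc2)c2ccccc12` gives 2480 nM. Compound 2 `CC1CCN(Cc2ccc3nc(NC(=O)N/N=C/c4cn(Cc5cccc(Cl)c5)c5ccccc45)sc3c2)CC1` gives 2810 nM, and compound 3 `CCN(CC)Cc1ccc2nc(NC(=O)N/N=C/c3c[nH]c4ccccc34)sc2c1` gives 3300 nM. Of these three numbers, compound 2 holds the second highest, yet its gap to compound 1 and its gap to compound 3 both lie inside the usual scatter of repeated measurements, so the three compounds cannot be told apart on the figures at hand.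

Compound 4 `CC1CCN(Cc2ccc3nc(NC(=O)N/N=C/c4cn(Cc5ccc(C(C)(C)C)cc5)c5ccccc45)sc3c2)CC1` has not yet been measured. It differs from compound 2 in a single place: 4-(tert-butyl)phenyl in place of 3-chlorophenyl on a saturated chain carbon bound to an aromatic nitrogen. Going by the values given here, no two of the measured compounds differ from each other in only one place, so there is no measured step to show what such a swap does in this assay. Among the compounds with values here, the three values that exist sit close together despite quite different structures, and that is the only guide available.

On that basis the step from compound 2 to compound 4 in this assay is expected to be a 1.0-fold lower number from compound 2 to compound 4 (0.00 log units; within the scatter), which is no change beyond the scatter. Compound 4 is therefore estimated to give 2800 nM in this assay, with a likely range from 1200 nM to 6500 nM.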

Compound 4, half-maximal inhibitory concentration: 3710 nM
Compound 4: the middle estimate sits 1.3-fold (0.12 log units) below what was measured, and the stated range covers the measured number.
By their numbers in this assay, from the lowest: compounds 1, 2, 3 and 4 (each within the scatter of the next).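

Going by these compounds alone, this pair gives the first measured step that changes one place alone: in this assay, moving from 3-chlorobenzyl to 4-(tert-butyl)benzyl gives a 1.3-fold higher number from compound 2 to compound 4 (0.12 log units; within the scatter) on the same core. On a saturated chain carbon bound to an aromatic nitrogen, then, 3-chlorophenyl and 4-(tert-butyl)phenyl cannot be told apart in this assay, even though the entering group has 10 heavy atoms against 7 and contains no chlorine. No supporting evidence is available to explain why the two groups give such similar readings.

Going by these compounds, whether the same holds for very different groups remains open, such as a benzyl group carrying an amine or a carboxylic acid, or a longer chain at this position. Within the data shown here, also open is whether this swap would read the same on another core, as this single pair of compounds is the only direct comparison of the two groups and cannot show how far the result extends.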